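A few compounds are considered here, and "the series" means these few. Any claim that something is new, unique, unknown or untested is made for them only; others in the source may bear on it.

Measured so far:
compound 1 `Cc1ccccc1OS(=O)(=O)c1ccc(N2CCN(C)C2=O)cc1` gives 4800 nM;
compound 2 `COc1ccccc1OS(=O)(=O)c1ccc(N2CCN(C)C2=O)cc1` gives 26000 nM;
compound 3 `Cc1cccc(OS(=O)(=O)c2ccc(N3CCN(C)C3=O)cc2)c1` gives 4300 nM.

All three numbers come from a functional assay on HT-29 cells (Homo sapiens) for antiproliferative activity, read by sulforhodamine B assay, with a stated time of 48 h; a higher number here means a weaker inhibitor, a lower number a stronger inhibitor. Compound 4 `COc1cccc(OS(=O)(=O)c2ccc(N3CCN(C)C3=O)cc2)c1` has not yet been measured. It differs from compound 3 by methoxy in place of methyl on an aromatic carbon, the same change seen between compound 1 and compound 2, where it gave a 5.4-fold higher number from compound 1 to compound 2 (0.73 log units; beyond the scatter). The two cores differ by 3-methylphenyl in place of 2-methylphenyl on an oxygen, a change that gave a 1.1-fold lower number from compound 1 to compound 3 (0.05 log units; within the scatter). The place is not identical: in compound 1 the group sits ortho to a large group, in compound 3 meta to a large group, so this counts as the same kind of change rather than the same one. The starting point is compound 3 at 4300 nM. For compound 4 the expected step is a 4.7-fold higher number from compound 3 to compound 4 (0.67 log units; beyond the scatter), resting on the earlier 5.4-fold higher number from compound 1 to compound 2 (0.73 log units; beyond the scatter), with extra room left for the different place. Compound 4 is therefore estimated at 20000 nM, between 6000 nM and 60000 nM.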

Compound 4, half-maximal inhibitory concentration: 2500 nM
Beside the measured number, compound 4's estimate is 8.0-fold (0.90 log units) above it; measured number below the stated range.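

In this assay, the swap of methyl for methoxy does not carry over from one core to the other: the same change on two cores in this assay, a 5.4-fold higher number (0.73 log units; beyond the scatter) from compound 1 to compound 2 and a 1.7-fold lower number (0.24 log units; within the scatter) from compound 3 to compound 4, 9.3-fold (0.97 log units) apart, beyond the scatter of two such steps. On the core of compound 3 the swap gives a 1.7-fold lower number from compound 3 to compound 4 (0.24 log units; within the scatter), and moving the methoxy group to give the 3-methoxyphenyl compound gives a 10-fold lower number from compound 2 to compound 4 (1.02 log units; beyond the scatter), while the change from the 2-methylphenyl compound gives a 1.9-fold lower number from compound 1 to compound 4 (0.28 log units; within the scatter). So the loss seen on the first core cannot be assumed on the second, but these two pairs do not show why the steps differ or how any further core would respond.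

The compounds shown leave open how an amine or a carboxylic acid would behave in place of methyl or methoxy on either core.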